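The source may report more compounds than this note shows. Statements on the series, on what has been measured and on what is new or still open speak of the compounds shown alone.

In an ADME assay on NCI-H460 cells (Homo sapiens) for cytotoxicity, read by MTT assay, with a stated time of 72 h (a higher number here means a weaker inhibitor of growth, a lower number a stronger inhibitor of growth), the measured compounds read:
- compound 1 `O=C(O)C1C(C(=O)NCC2Cc3ccsc3CO2)[C@H]2CC[C@@H]1O2`: 10000 nM
- compound 2 `CCCCNC(=O)C1C(C(=O)O)[C@@H]2CC[C@H]1O2`: 10000 nM
- compound 3 `CCc1ccccc1NC(=O)C1C(C(=O)O)[C@@H]2CC[C@H]1O2`: 10000 nM

Compound 2 stands level with compound 1 and compound 3, with nothing separating them beyond the usual scatter. Compound 4 `CCCCCCCCNC(=O)C1C(C(=O)O)[C@@H]2CC[C@H]1O2` departs from compound 2 by one change (butyl in place of hydrogen on a saturated chain carbon, four bonds along the chain from an amide-type nitrogen) on the amide side chain. For the measured compounds named here, no step between measured compounds differing in one place is available. Going by the values given here, the only guide is that compound 3, with another amide group, gives 10000 nM, the same as compound 2. In this assay a small move towards stronger growth inhibition, or none beyond the scatter, is therefore expected. The estimated change is a 1.4-fold lower number from compound 2 to compound 4 (0.15 log units; within the scatter), and it may not clear the scatter. Compound 4 is estimated at 7000 nM, with an expected range from 2500 nM to 20000 nM.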

Compound 4, concentration for 50% growth inhibition: 10000 nM
For compound 4 the middle estimate is 1.4-fold (0.15 log units) below the measured one, within the range that was stated.
By their numbers in this assay, from the lowest: compounds 1, 2, 3 and 4 (each within the scatter of the next).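

The step reads no change at the digits printed from compound 2 to compound 4 (within the scatter) in this assay for butyl in place of hydrogen on a saturated chain carbon, four bonds along the chain from an amide-type nitrogen. The earlier compounds shown here gave no step at this place, and this one shows that the longer chain on the amide side does not move the number beyond the scatter. Nothing measured here speaks to why the number stays level.

On these data alone, whether an amine on the amide side chain, or a chain longer than that of compound 4, would separate from these values remains open.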